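Cytotoxicity notes on a small series

A few compounds are considered here, and "the series" means these few. Any claim that something is new, unique, unknown or untested is made for them only; others in the source may bear on it.

Measured so far:
compound 1 `Cc1nc(-c2ccc(Cl)cc2)sc1C(=O)CSc1nc(-c2ccccc2)c(C#N)c(=O)[nH]1` — "not determined" (no result reported)
compound 2 `Cc1nc(-c2ccc(Cl)cc2)sc1C(=O)CSc1nc(-c2cccc(Cl)c2)c(C#N)c(=O)[nH]1` — 30100 nM

In an ADME assay on HEK293 cells (Homo sapiens) for cytotoxicity, read by MTT assay, with a stated time of 48 h (a lower number here means a stronger inhibitor, a higher number a weaker inhibitor), compound 1 gives "not determined" (no result reported), so compound 1 stands without a number of its own. In this assay, among the compounds with values here, compound 2 gives 30100 nM, a weak result, and it is the only number in hand. Compound 3 `Cc1nc(-c2ccccc2)sc1C(=O)CSc1nc(-c2ccccc2)c(C#N)c(=O)[nH]1` differs from compound 1 by hydrogen in place of chloro on an aromatic carbon. Within the data shown here, no measured pair frames this step, so the size of the change from compound 1 to compound 3 in this assay is expected to be small, likely within the scatter, without a clear direction. Compound 3 is therefore estimated at 35000 nM, within 12000 nM to 100000 nM.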

Compound 3, half-maximal inhibitory concentration: 93500 nM
Compound 3: the middle estimate sits 2.7-fold (0.43 log units) below what was measured, and the stated range covers the measured number.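

In this assay, within the data shown here, compound 1 has no number of its own, so no step to compound 3 can be read. The compounds shown leave open what the 4-chlorophenyl to phenyl change does here. No supporting data bear on this result.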